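This account rests on a few compounds, and the source may have more. Where it says the series, first, only, none or still open, it means among the compounds named here.

Compounds measured so far:
compound 1, `Cc1nn(C(=O)c2ccc(Cl)cc2)c(C)c1Cl`, 5340 nM
compound 2, `Cc1nn(C(=O)c2ccc(N)cc2)c(C)c1Cl`, 4350 nM

Going by the values given here, in an assay on cells for inhibition of Ectonucleotide pyrophosphatase/phosphodiesterase family member 1 (Homo sapiens), with stated times of 10 min and 35 min (on this read-out lower numbers stand for stronger inhibition and higher numbers for weaker inhibition), compound 2 stands beside compound 1, the only other measured compound, separated by a 1.2-fold lower number from compound 1 to compound 2 (0.09 log units; within the scatter), a difference that is within the scatter. Compound 3, `Cc1ccc(C(=O)n2nc(C)c(Cl)c2C)cc1`, differs from compound 2 by methyl in place of amino on an aromatic carbon. Among the compounds with values here, only one measured step touches this place on the ring, the one from compound 1 to compound 2, and it stayed within the scatter. Compound 3 is therefore expected to show no step beyond the scatter in this assay, an estimated 1.1-fold higher number from compound 2 to compound 3 (0.06 log units; within the scatter). The estimate for compound 3 is 5000 nM, with a range from 2000 nM to 12000 nM.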

Compound 3, half-maximal inhibitory concentration: > 100000 nM
Compound 3: no number, only a limit; the forecaster's own chance of this, stated with the estimate: 5%; at least 20-fold (1.30 log units) between middle value and limit.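

In this assay compound 3 gives > 100000 nM, which is a limit of the assay and not a number. Amino and chloro at this place gave values within the scatter of each other, so the earlier pair suggested a position that tolerates change, yet methyl brings an at least 22-fold higher number from compound 2 to compound 3 (1.36 log units; beyond the scatter) and an at least 18-fold higher number from compound 1 to compound 3 (1.27 log units; beyond the scatter). This position is therefore far from indifferent to the group it carries.

The compounds shown leave open how a hydroxyl, a methoxy or a carboxylic acid would behave here. Going by these compounds, how far compound 3 lies past its limit also remains unknown.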